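Tert-butoxy in place of isopropylsulfanyl on a shared core

The source may report more compounds than this note shows. Statements on the series, on what has been measured and on what is new or still open speak of the compounds shown alone.

Three compounds share one core: compound 1 `Cc1cc(C)c(S(C)(=O)=O)cc1C(=O)N=C(N)N`, compound 2 `Cc1cc(-c2ccccc2)c(S(C)(=O)=O)cc1C(=O)N=C(N)N` and compound 3 `Cc1cc(SC(C)C)c(S(C)(=O)=O)cc1C(=O)N=C(N)N`. In a functional assay for inhibition of sodium/hydrogen exchanger (Oryctolagus cuniculus) (a higher number here means a weaker inhibitor, a lower number a stronger inhibitor), compound 1 gives 11 nM, compound 2 gives 19 nM and compound 3 gives 12 nM. Compound 3 thus stands second highest of the three numbers, and both of its steps, a 1.1-fold higher number from compound 1 to compound 3 (0.04 log units; within the scatter) and a 1.6-fold lower number from compound 2 to compound 3 (0.20 log units; within the scatter), fall within the scatter. Compound 4 `Cc1cc(OC(C)(C)C)c(S(C)(=O)=O)cc1C(=O)N=C(N)N` carries a change on the same aromatic carbon: tert-butoxy in place of isopropylsulfanyl on an aromatic carbon. The step of a 1.1-fold higher number from compound 1 to compound 3 (0.04 log units; within the scatter), which changed that same aromatic carbon, is the nearest guide and showed no shift beyond the scatter; a 1.7-fold higher number from compound 1 to compound 2 (0.24 log units; within the scatter) likewise stayed within it. Compound 4 is therefore expected to show no step beyond the scatter, a 1.1-fold higher number from compound 3 to compound 4 (0.03 log units; within the scatter). The estimate for compound 4 in this assay is 13 nM, within 5 nM to 35 nM.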

Compound 4, half-maximal inhibitory concentration: 9.4 nM
Estimate against measurement, compound 4: 1.4-fold (0.14 log units) above; the measured number falls inside the stated range.
By their numbers in this assay, from the lowest: compounds 4, 1, 3 and 2 (each within the scatter of the next, the first and the last beyond it).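

In this assay tert-butoxy, on the aromatic carbon ortho to a methylsulfonyl group, stays level with both isopropylsulfanyl and methyl, with a 1.3-fold lower number from compound 3 to compound 4 (0.11 log units; within the scatter) and a 1.2-fold lower number from compound 1 to compound 4 (0.07 log units; within the scatter). Against phenyl the change gives a 2.0-fold lower number from compound 2 to compound 4 (0.31 log units; beyond the scatter), the first step at this position to pass the scatter, though only modestly. Nothing available explains this small separation. The compounds shown leave open whether an amine or a carboxylic acid on this carbon would stay at the same level. They also leave open how a longer alkoxy chain would compare with tert-butoxy.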